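Methyl to phenyl on the amino nitrogen of compound 1

The source may hold more compounds than are shown below. What is called first, only, known or untested is meant among the compounds shown, and "the series" means these compounds.

Measured compounds:
compound 1, `CCOc1ccc(NC(=O)c2c(N)n[nH]c2NC)cc1`: 7900 nM
compound 2, `CCOc1ccc(-n2nnc3n[nH]c(NC)c3c2=O)cc1`: 12400 nM

Of the compounds shown here, two have been measured in a functional assay on CCRF-CEM cells (Homo sapiens) for cytotoxicity, read by resazurin assay, with a stated time of 48 h; on this read-out higher numbers stand for weaker inhibition and lower numbers for stronger inhibition. Compound 1 gives 7900 nM. The core of compound 1 differs from that of compound 2, which gives 12400 nM. The gap between these two numbers lies within the usual scatter of repeated measurements, so compound 1 is not separated from compound 2 by the data; the two simply share a weak level of cytotoxicity on this cell line.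

Compound 3, `CCOc1ccc(NC(=O)c2c(N)n[nH]c2Nc2ccccc2)cc1`, has not yet been measured in this assay. It differs from compound 1 in one place: phenyl in place of methyl on a nitrogen on an aromatic ring. The rest of the molecule, the ethoxyphenyl amide and the shared core, is unchanged.

Going by the values given here, no pair of measured compounds shows this kind of change, so there is no measured step to lean on. Without such a precedent, a step in either direction that clears the scatter is possible, but a modest move is the more cautious expectation. Compound 3 is therefore estimated at 5000 nM, with a range from 1500 nM to 16000 nM, which would mean an expected step of a 1.6-fold lower number from compound 1 to compound 3 (0.20 log units; within the scatter).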

Compound 3, half-maximal inhibitory concentration: 4470 nM
The estimate for compound 3 lay 1.1-fold (0.05 log units) above the measured number, within the range that was stated.
By their numbers in this assay, from the lowest: compounds 3, 1 and 2 (each within the scatter of the next, the first and the last beyond it).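

In this assay, replacing methyl with phenyl on a nitrogen on an aromatic ring gives a 1.8-fold lower number from compound 1 to compound 3 (0.25 log units; within the scatter) and so does not separate the two compounds. Going by these compounds alone, this is the first measured change at this position, and it shows that methylamino to anilino, which brings in a six-membered aromatic ring of carbon only and five more heavy atoms, leaves the cytotoxicity on this cell line at a level the data cannot tell from that of compound 1. No independent measurement is available that would explain this outcome.

The compounds shown leave open whether any other group on this nitrogen, such as a benzyl group, a cyclohexyl ring, a longer chain like n-butyl or a phenyl carrying a methoxy group or a chlorine atom, would produce a step that clears the usual scatter. They also leave open whether anilino in place of methylamino would have a similar outcome on the core of compound 2, where only the methylamino form is shown.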